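The source may hold more compounds than are shown below. What is called first, only, known or untested is meant among the compounds shown, and "the series" means these compounds.

In a functional assay on P388/ADR cells (Mus musculus) for inhibition (on this read-out higher numbers stand for weaker inhibition of growth and lower numbers for stronger inhibition of growth), compound 1 (`CN(C)c1ccc(NS(=O)(=O)c2c(F)c(F)c(F)c(F)c2F)cc1`) gives 36 nM while compound 2 (`Cc1ccc(NS(=O)(=O)c2c(F)c(F)c(F)c(F)c2F)cc1C`) gives 110 nM in the same test. Compound 1 therefore has the lower of the two numbers, and the gap lies beyond the usual scatter, so it inhibits growth more strongly than compound 2 does. Compound 3 (`COc1ccc(NS(=O)(=O)c2c(F)c(F)c(F)c(F)c2F)cc1`) has not yet been measured. It keeps the core of compound 1 but carries methoxy in place of dimethylamino on an aromatic carbon. For the measured compounds named here, no measured pair shows this change alone, so the evidence is thin. A small move towards a higher number is expected, one that may stay within the scatter. The estimated change is a 1.9-fold higher number from compound 1 to compound 3 (0.29 log units; within the scatter) on this reasoning. In this assay the estimate for compound 3 is 70 nM with an expected range from 25 nM to 200 nM across repeated measurements.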

Compound 3, concentration for 50% growth inhibition: 34 nM
For compound 3 the middle estimate is 2.1-fold (0.31 log units) above the measured one; the measured number falls inside the stated range.
By their numbers in this assay, from the lowest: compounds 3 and 1 (each within the scatter of the next); then compound 2.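

In this assay, putting methoxy in place of dimethylamino on this aromatic carbon, para to a large group, leaves the result within the scatter (a 1.1-fold lower number from compound 1 to compound 3 (0.02 log units; within the scatter)). For the compounds shown here, compound 1 and compound 2 differ in more than one place, so only this new pair isolates a single change, and it shows that at this position a group of 2 heavy atoms with oxygen matches one of 3 heavy atoms with nitrogen. Nothing available explains why the two groups give matching results.

On these data alone, what a carboxylic acid or a longer chain such as butoxy would do on this same carbon remains open. As far as these compounds go, whether the match between methoxy and dimethylamino holds on any other core also remains open, since this is a single pair.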